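Piperidinyl for iodoanilino on the enone ring carbon

This account rests on a few compounds, and the source may have more. Where it says the series, first, only, none or still open, it means among the compounds named here.

Compound 1 `O=C1C(Nc2ccc(I)cc2)=CC(=O)c2c1nc1n2[C@H]2OC[C@@H](O)[C@H]2OC1` and compound 3 `O=C1C=C(Nc2ccc(I)cc2)C(=O)c2c1nc1n2[C@H]2OC[C@@H](O)[C@H]2OC1` are built from the same atoms joined differently; the difference between the two cores is not broken down here. In a functional assay on ECa-109 cells for inhibition, with ECa-109 cell line (Homo sapiens) as the target, read by sulforhodamine B assay (on this read-out lower numbers stand for stronger inhibition and higher numbers for weaker inhibition), compound 1 gives 2530 nM. Compound 3 gives 2300 nM in this assay, a number that lies within the scatter of compound 1, so no order between the two is claimed. Compound 2 `O=C1C(N2CCCCC2)=CC(=O)c2c1nc1n2[C@H]2OC[C@@H](O)[C@H]2OC1` arises from compound 1 by piperidin-1-yl in place of (4-iodophenyl)amino on a double-bonded ring carbon. For compound 2 this assay reports only a limit, > 8000 nM. The resulting step, an at least 3.1-fold higher number from compound 1 to compound 2 (0.49 log units; beyond the scatter), rests on that limit of > 8000 nM in this assay, at which 1 of the 3 values shown sits, and is therefore known only as a lower bound.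

Compound 4 `O=C1C=C(N2CCCCC2)C(=O)c2c1nc1n2[C@H]2OC[C@@H](O)[C@H]2OC1` is not yet measured; it arises from compound 3 by piperidin-1-yl in place of (4-iodophenyl)amino on a double-bonded ring carbon, the same change at the same place as before. Given an at least 3.1-fold higher number from compound 1 to compound 2 (0.49 log units; beyond the scatter), the same change is expected to produce a 4.3-fold higher number from compound 3 to compound 4 (0.64 log units; beyond the scatter). For compound 4 the expected value in this assay is 10000 nM, with a range from 4500 nM to 30000 nM, and a reported limit rather than a number is considered likely.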

Compound 4, half-maximal inhibitory concentration: > 8000 nM
Compound 4 was reported as a limit; the forecaster's own chance of this, stated with the estimate: 70%; the middle value is on the limit's open side.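

On the core of compound 3, piperidin-1-yl in place of (4-iodophenyl)amino gives an at least 3.4-fold higher number from compound 3 to compound 4 (0.54 log units; beyond the scatter) in this assay. The direction of the change thus carries over between the two cores in this pair of examples, and the two steps stand side by side as follows: the same change on two cores in this assay, an at least 3.1-fold higher number (0.49 log units; beyond the scatter) from compound 1 to compound 2 and an at least 3.4-fold higher number (0.54 log units; beyond the scatter) from compound 3 to compound 4; the limit leaves it open whether they differ Both piperidin-1-yl compounds are reported only as limits, so the data show neither the true size of the change on either core nor whether that size is the same on both: the limit of > 8000 nM in this assay, at which 2 of the 4 values shown sit.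

The compounds shown leave open which part of (4-iodophenyl)amino matters on these cores, the iodine, the aromatic ring or the amine hydrogen. An unsubstituted anilino group, a 4-chloroanilino group, a benzylamino group or an open-chain amine such as dimethylamino on each core would separate these parts, and a value below the limit would be needed before any difference between the cores could be read.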